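Replacing 2-hydroxyethyl with (oxan-3-yl)carbonyl on compound 3

The source may report more compounds than this note shows. Statements on the series, on what has been measured and on what is new or still open speak of the compounds shown alone.

Measured in a functional assay on HeLa cells (Homo sapiens) for cytotoxicity, read by MTT assay; a lower number here means a stronger inhibitor, a higher number a weaker inhibitor:
compound 1 `CC(C)=CC[C@@H](OC[C@H](C)O)C1=CC(=O)c2c(O)ccc(O)c2C1=O` gives 40300 nM
compound 2 `CC(C)=CC[C@@H](OC(=O)c1ccco1)C1=CC(=O)c2c(O)ccc(O)c2C1=O` gives 80300 nM
compound 3 `CC(C)=CC[C@@H](OCCO)C1=CC(=O)c2c(O)ccc(O)c2C1=O` gives 18600 nM

Compound 3 at 18600 nM has the lowest number of the three. Compound 4 `CC(C)=CC[C@@H](OC(=O)C1CCCOC1)C1=CC(=O)c2c(O)ccc(O)c2C1=O` carries the change (oxan-3-yl)carbonyl in place of 2-hydroxyethyl on an oxygen on a saturated carbon with (oxan-3-yl)carbonyl in place of 2-hydroxyethyl on an oxygen on a saturated carbon. The closest measured step is a 4.3-fold lower number from compound 2 to compound 3 (0.64 log units; beyond the scatter) and, read in reverse, it also takes 2-hydroxyethyl away in favour of a carbonyl-linked ring group. The steps of a 2.0-fold higher number from compound 1 to compound 2 (0.30 log units; within the scatter) and a 2.2-fold lower number from compound 1 to compound 3 (0.34 log units; beyond the scatter) bear on it less directly. The expected step is therefore modest, a 2.7-fold higher number from compound 3 to compound 4 (0.43 log units; beyond the scatter) in this assay as estimated. Compound 4 is estimated at 50000 nM with an expected range of 20000 nM to 120000 nM for its measurement.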

Compound 4, half-maximal inhibitory concentration: 60500 nM
The estimate for compound 4 lay 1.2-fold (0.08 log units) below the measured number; the measured number falls inside the stated range.
By their numbers in this assay, from the lowest: compound 3; then compounds 1, 4 and 2 (each within the scatter of the next).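

In this assay, (oxan-3-yl)carbonyl in place of 2-hydroxyethyl gives a 3.3-fold higher number from compound 3 to compound 4 (0.51 log units; beyond the scatter) and so shows that the loss seen with (furan-2-yl)carbonyl is not confined to that one carbonyl-linked ring. Oxan-3-yl in place of furan-2-yl on the carbonyl carbon gives a 1.3-fold lower number from compound 2 to compound 4 (0.12 log units; within the scatter) and so separates these two rings by no more than the scatter. Against 2-hydroxypropyl, (oxan-3-yl)carbonyl gives a 1.5-fold higher number from compound 1 to compound 4 (0.18 log units; within the scatter) and so stands no clearer of that group. As far as these compounds go, whether an amine, a carboxylic acid or a longer chain ending in hydroxyl would match 2-hydroxyethyl at this oxygen remains open. No evidence is available on what lies behind these steps.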